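Isoquinolinyl amide in place of a chlorocinnamamide on a dopamine scaffold

The source may hold more compounds than are shown below. What is called first, only, known or untested is meant among the compounds shown, and "the series" means these compounds.

Compound 1 `CCCN(CC[C@H]1CC[C@H](NC(=O)/C=C/c2cccc(Cl)c2)CC1)[C@H]1CCc2nc(N)sc2C1` is the reference point of this small set. In an assay on brain for displacement of a labelled ligand from D(3) dopamine receptor (Rattus norvegicus) (a lower number here means a stronger inhibitor, a higher number a weaker inhibitor), compound 1 gives 1.2 nM, the lowest of the three numbers. Compound 2 `CCCN(CC[C@H]1CC[C@H](NC(=O)/C=C/c2ccc(OC)cc2)CC1)[C@H]1CCc2nc(N)sc2C1` gives 6.7 nM in this assay, and compound 3 `CCCN(CC[C@H]1CC[C@H](NC(=O)/C=C/c2ccccc2OC)CC1)[C@H]1CCc2nc(N)sc2C1` gives 8.1 nM. The steps of a 5.6-fold higher number from compound 1 to compound 2 (0.75 log units; beyond the scatter) and a 6.8-fold higher number from compound 1 to compound 3 (0.83 log units; beyond the scatter) show that changing the substituent on the aryl ring of the cinnamoyl group costs affinity, while a 1.2-fold higher number from compound 2 to compound 3 (0.08 log units; within the scatter) shows the two methoxy isomers cannot be told apart.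

Compound 4 `CCCN(CC[C@H]1CC[C@H](NC(=O)c2cccc3cnccc23)CC1)[C@H]1CCc2nc(N)sc2C1` differs from compound 1 by isoquinolin-5-yl in place of 2-(3-chlorophenyl)ethenyl on a carbonyl carbon. For the measured compounds named here, no measured step removes the ethenyl chain or installs a fused bicyclic aryl, so the two aryl-substituent steps are only a loose guide: they indicate that the chlorophenyl group of compound 1 is a favourable arrangement and that departures from it have so far given higher numbers. A modest loss is therefore expected, an 8.3-fold higher number from compound 1 to compound 4 (0.92 log units; beyond the scatter), and compound 4 is estimated at 10 nM in this assay, within 2 nM to 50 nM.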

Compound 4, inhibition constant: 5.9 nM
Beside the measured number, compound 4's estimate is 1.7-fold (0.23 log units) above it, and the stated range covers the measured number.
By their numbers in this assay, from the lowest: compound 1; then compounds 4, 2 and 3 (each within the scatter of the next).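

In this assay, the carbonyl carbon accepts isoquinolin-5-yl in place of the whole 2-(3-chlorophenyl)ethenyl group at a modest cost, a 4.9-fold higher number from compound 1 to compound 4 (0.69 log units; beyond the scatter), so a low number at this position does not depend on the ethenyl chain. The change also puts compound 4 level with the methoxy compounds, with a 1.4-fold lower number from compound 3 to compound 4 (0.14 log units; within the scatter) and a 1.1-fold lower number from compound 2 to compound 4 (0.06 log units; within the scatter), which leaves compound 1 as the only one set apart from the others. Nothing available accounts for this result.

As far as these compounds go, it remains open whether the ring nitrogen of isoquinolin-5-yl contributes at all, a question that a naphthyl group on the same carbonyl carbon would address. A 3-chlorophenyl group bound directly to the carbonyl carbon would likewise separate the part played by the ethenyl chain from that of the chlorine.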